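The source may report more compounds than this note shows. Statements on the series, on what has been measured and on what is new or still open speak of the compounds shown alone.

In an ADME assay on HEK293 cells (Homo sapiens) for cytotoxicity, read by fluorescence and resazurin assay, with a stated time of 24 h (a lower number here means that less compound is tolerated, a higher number that more compound is tolerated), compound 1 (`O=S1(=O)C=C(Sc2nnc(C3CCCCC3)o2)c2ccccc21`) gives 3000 nM while compound 2 (`COC(=O)c1ccc(-c2nnc(SC3=CS(=O)(=O)c4ccccc43)o2)cc1`) gives 4000 nM and compound 3 (`COc1ccc(-c2nnc(SC3=CS(=O)(=O)c4ccccc43)o2)cc1`) gives 2000 nM as its half-maximal cytotoxic concentration. On these numbers compound 3 cannot be set apart from the other two.

Compound 4 (`O=S1(=O)C=C(Sc2nnc(-c3cccc(Cl)c3)o2)c2ccccc21`) has 3-chlorophenyl in place of 4-methoxyphenyl on an aromatic carbon of the five-membered aromatic ring with 2 nitrogen and 1 oxygen, and the computed difference reads 3-chlorophenyl in place of 4-methoxyphenyl on an aromatic carbon for this swap. Going by the values given here, two measured steps bear on it. The swap of 4-methoxyphenyl in place of cyclohexyl at that same carbon shows a 1.5-fold lower number from compound 1 to compound 3 (0.18 log units; within the scatter) and is the closer precedent. Methoxy in place of methoxycarbonyl on an aromatic carbon shows a 2.0-fold lower number from compound 2 to compound 3 (0.30 log units; within the scatter) as the second precedent. Neither step leaves the scatter, though three compounds are a thin basis for any reading.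

The expected result for the new swap is a 1.3-fold higher number from compound 3 to compound 4 (0.10 log units; within the scatter) with no change beyond the scatter estimated in either direction. Compound 4 is estimated at 2500 nM with an expected range from 1000 nM to 6000 nM in this assay for now.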

Compound 4, half-maximal cytotoxic concentration: 6000 nM
The estimate for compound 4 lay 2.4-fold (0.38 log units) below the measured number; low and high end bracket the measured number.
By their numbers in this assay, from the lowest: compounds 3, 1, 2 and 4 (each within the scatter of the next, the first and the last beyond it).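

Notes on the aromatic carbon of the five-membered aromatic ring with 2 nitrogen and 1 oxygen: in this assay, a 3.0-fold higher number from compound 3 to compound 4 (0.48 log units; beyond the scatter) is the first step at this carbon to pass the scatter, so the group held there can move the number in a way that the earlier steps could not show. The same 3-chlorophenyl set against cyclohexyl gives a 2.0-fold higher number from compound 1 to compound 4 (0.30 log units; within the scatter), so the readable change is confined to the comparison with 4-methoxyphenyl and does not extend to an aromatic ring over a saturated one. No measurement to hand accounts for the step between 4-methoxyphenyl and 3-chlorophenyl.

That step changes both the substituent and its place on the phenyl ring, so the compounds shown cannot say whether the chlorine or its placement carries the difference. Also open, from the compounds shown here alone, is how an amine or a carboxylic acid on that phenyl ring, or a longer alkyl chain at the same carbon, would read in this assay.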